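Furan in Place of a Fluoromethoxyphenyl: Expected Solubility

The source may report more compounds than this note shows. Statements on the series, on what has been measured and on what is new or still open speak of the compounds shown alone.

Compound 1 `COc1ccc(F)cc1CNCCCNc1ccnc2cc(Cc3ccc(C#N)cc3)ccc12` stands lowest of the two numbers in hand in a physicochemical assay for solubility, with a stated time of 18 h, at pH 7.4 (a higher number here means a more soluble compound, a lower number a less soluble compound), where compound 1 gives 4200 nM. Its nearest neighbour, compound 2 `COc1ccc(F)cc1CNCCCNc1ccnc2cc(-c3ccccc3)ccc12`, gives 32000 nM in this assay, so that the step of a 7.6-fold higher number from compound 1 to compound 2 (0.88 log units; beyond the scatter) lies beyond the scatter. Compound 3 `N#Cc1ccc(Cc2ccc3c(NCCCNCc4ccco4)ccnc3c2)cc1` differs from compound 1 at another site: furan-2-yl in place of 5-fluoro-2-methoxyphenyl on a saturated chain carbon bound to an amine nitrogen. Within the data shown here, no measured step touches this site, so the single step in hand, from compound 1 to compound 2, bears on it only loosely, showing that one swap of an aromatic group produced a modest shift. With nothing closer to lean on, compound 3 is expected to sit near compound 1 or somewhat higher. Compound 3 is therefore expected to show a step of a 1.9-fold higher number from compound 1 to compound 3 (0.28 log units; within the scatter), small enough that it may or may not exceed the scatter. Compound 3 is estimated at 8000 nM, within a range from 2500 nM to 25000 nM.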

Compound 3, solubility: 4200 nM
Compound 3: the middle estimate sits 1.9-fold (0.28 log units) above what was measured; the range from low to high includes it.
By their numbers in this assay, from the lowest: compounds 1 and 3 (each within the scatter of the next); then compound 2.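

In this assay, among these compounds, the furan-2-yl swap on a saturated chain carbon bound to an amine nitrogen gives (no change at the digits printed from compound 1 to compound 3 (within the scatter)), the first reading at this position. Trading the six-membered aromatic ring of 5-fluoro-2-methoxyphenyl for the five-membered ring of furan-2-yl, with fewer heavy atoms, therefore leaves the number where it stood, whereas phenyl in place of 4-cyanobenzyl on an aromatic carbon gave (a 7.6-fold higher number from compound 1 to compound 2 (0.88 log units; beyond the scatter)). No measurement in hand speaks to why this position behaves as it does.

On these data alone, whether a pyridine ring or a carboxylic acid at this place would move the number remains open. So does whether the furan-2-yl swap would read the same on compound 2, which carries phenyl rather than 4-cyanobenzyl.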